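Chalcone series on hepatoma cells: dichlorophenyl replacement

The source may hold more compounds than are shown below. What is called first, only, known or untested is meant among the compounds shown, and "the series" means these compounds.

Measured so far:
compound 1, `COc1ccc(/C=C/C(=O)c2ccc(OC)c3c2OC(C)(C)C=C3)c(F)c1`: 7560 nM
compound 2, `COc1cc(OC)c(OC)cc1/C=C/C(=O)c1ccc(OC)c2c1OC(C)(C)C=C2`: > 10000 nM

For the measured compounds named here, in a functional assay on HepG2 cells (Homo sapiens) for antiproliferative activity, read by MTT assay, with a stated time of 24 h (on this read-out lower numbers stand for stronger inhibition and higher numbers for weaker inhibition), compound 1 gives 7560 nM, the only numerical value obtained so far. Compound 2 gives > 10000 nM in this assay, which is a limit of the assay and not a number; this is the limit of > 10000 nM in this assay, at which 1 of the 2 values shown sits. Compound 3, `COc1ccc(C(=O)/C=C/c2ccc(Cl)c(Cl)c2)c2c1C=CC(C)(C)O2`, differs from compound 1 by 3,4-dichlorophenyl in place of 2-fluoro-4-methoxyphenyl on a double-bonded chain carbon bound to a double-bonded chain carbon. Going by the values given here, no step between measured compounds is available to calibrate this change. The change is expected to give a 1.7-fold lower number from compound 1 to compound 3 (0.23 log units; within the scatter), a modest move toward stronger inhibition that may not clearly exceed the usual scatter. Compound 3 is estimated at 4500 nM, within 1500 nM to 10000 nM.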

Compound 3, half-maximal inhibitory concentration: > 10000 nM
Compound 3 was reported as a limit; the forecaster's own chance of this, stated with the estimate: 25%; middle value at least 2.2-fold (0.34 log units) away from the limit.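

In this assay, an at least 1.3-fold higher number from compound 1 to compound 3 (0.12 log units; that floor lies within the scatter), giving this position its first step, though only as a floor. Compound 3 gives > 10000 nM, which is a limit of the assay and not a number. The 3,4-dichlorophenyl change therefore shows no move toward stronger inhibition, and compound 1 still holds the only numerical value: the limit of > 10000 nM in this assay, at which 2 of the 3 values shown sit.

On these data alone, how far compound 3 lies beyond the limit stays open, and with it the true size of the step. Also open, as far as these compounds go, is whether an amine or a carboxylic acid at this place would give a numerical value.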